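A few compounds are considered here, and "the series" means these few. Any claim that something is new, unique, unknown or untested is made for them only; others in the source may bear on it.

Measured compounds:
compound 1, `NC[C@@H]1CCCc2cc(S(=O)(=O)c3cc[nH]c3)ccc21`, 0.316 nM
compound 2, `O=C(NC[C@@H]1CCCc2cc(S(=O)(=O)c3cccc(F)c3)ccc21)c1ncc[nH]1`, 15.9 nM

In an assay on isolated protein for displacement of a labelled ligand from 5-hydroxytryptamine receptor 6 (Homo sapiens) (on this read-out lower numbers stand for stronger inhibition and higher numbers for weaker inhibition), compound 1 gives 0.316 nM, and compound 2 gives 15.9 nM. For the measured compounds named here, of the two numbers, that of compound 2 is the higher one, and the gap to compound 1, its only neighbour here, lies beyond the scatter of repeated measurements. Going by the values given here, the two compounds differ in more than one place, so no single step between them is traced.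

Compound 3, `N=C(N)NC(=O)C[C@@H]1CCCc2cc(S(=O)(=O)c3cccc(F)c3)ccc21`, has not yet been measured in this assay. It differs from compound 2 in one place: a group of 6 heavy atoms (2 carbon, 3 nitrogen, 1 oxygen; no ring) in place of a group of 8 heavy atoms (4 carbon, 3 nitrogen, 1 oxygen; one five-membered aromatic ring with 2 hetero atoms), on a saturated chain carbon bound to a saturated ring carbon. Among the compounds with values here, the change keeps the rest of the shared core of compound 2 untouched, and no measured pair with this same change is at hand, so the size of the step can only be guessed.

The account expects a small step from compound 2 to compound 3, toward a lower number, of about a 2.0-fold lower number from compound 2 to compound 3 (0.30 log units; within the scatter), a change that may not rise above the scatter. Compound 3 is therefore estimated to give 8 nM in this assay, with a range from 2 nM to 40 nM.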

Compound 3, inhibition constant: 0.631 nM
Estimate against measurement, compound 3: 13-fold (1.10 log units) above, outside the stated range (below it).
By their numbers in this assay, from the lowest: compounds 1 and 3 (each within the scatter of the next); then compound 2.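

In this assay, the saturated chain carbon bound to a saturated ring carbon proves to be a place where the choice of group matters greatly: putting a group of 6 heavy atoms with no ring in place of the ((1H-imidazol-2-yl)carbonyl)amino group gives a 25-fold lower number from compound 2 to compound 3 (1.40 log units; beyond the scatter) and so a large step. The five-membered aromatic ring with 2 hetero atoms is therefore not required here for a low number, and compound 3, with no ring in this group, reaches a value in the sub-nanomolar range (0.631 nM). No accompanying measurement bears on this step, and what lies behind its size remains unexplained.

The compounds shown leave open whether the whole entering group is needed or only part of it, which a plain amine or a carboxylic acid on the same chain carbon would help to settle. Going by these compounds, it also remains open whether the same change would give a step of similar size on the core of compound 1, which differs from compound 3 in more than one place.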